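Swapping a methoxy-bearing benzyl ether for a phenethyl ether

The source may hold more compounds than are shown below. What is called first, only, known or untested is meant among the compounds shown, and "the series" means these compounds.

Compound 1 `CCC1(Cc2ccccc2)OS(=O)(=O)C=C1OCc1ccc(OC)cc1` carries a 4-methoxyphenyl group on a saturated chain carbon bound to an oxygen on an unsaturated carbon of the shared core. In an ADME assay on HEL cells (Homo sapiens) for cytotoxicity, with a stated time of 3 days (a higher number here means that more compound is tolerated, a lower number that less compound is tolerated), compound 1 gives >= 200000 nM, which is a limit of the assay rather than a measured number. Compound 2 `CCC1(Cc2ccccc2)OS(=O)(=O)C=C1OC` carries only hydrogen in that place; in this assay compound 2 gives > 400000 nM, again a limit. Compound 3 `CCC1(Cc2ccccc2)OS(=O)(=O)C=C1OCCCCCCc1ccccc1` carries a longer phenylalkyl ether; in this assay compound 3 gives >= 20000 nM, also a limit. Among the measured compounds shown here, the only step that pairs two of these, a step that the two limits leave unreadable from compound 1 to compound 2, cannot be sized, since both ends are limits. For the measured compounds named here, all three results sit at limits (the limit of > 400000 nM in this assay, at which 1 of the 3 values shown sits, (the limit of >= 20000 nM in this assay, at which 1 of the 3 values shown sits), (the limit of >= 200000 nM in this assay, at which 1 of the 3 values shown sits)), so no measured step gives a readable size for any change in this place.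

Compound 4 `CCC1(Cc2ccccc2)OS(=O)(=O)C=C1OCCc1ccccc1` differs from compound 1 in one place: benzyl in place of 4-methoxyphenyl on a saturated chain carbon bound to an oxygen on an unsaturated carbon. Without a readable step to lean on, and with compound 1 and compound 3 both at limits, the expected step of a number no higher from compound 1 to compound 4 (the limit leaves the size open) is no more than the scatter, with a likely limit again. Compound 4 is therefore expected to give about 200000 nM, within a range from 50000 nM to 400000 nM.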

Compound 4, minimum cytotoxic concentration: >= 20000 nM
Compound 4: no number, only a limit (the forecaster's own chance of this, stated with the estimate: 70%); the middle value does not contradict the limit.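

Compound 4, like compound 1 and compound 2, stands at a limit of this assay, and neither the step from compound 1 to compound 4 nor the step from compound 2 to compound 4 can be read. The compounds shown leave open the concentration at which any of them becomes toxic to these cells, and whether changing the group at this place alters tolerance at all.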